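A few compounds are considered here, and "the series" means these few. Any claim that something is new, unique, unknown or untested is made for them only; others in the source may bear on it.

Measured compounds:
compound 1 `N[C@H]1CC[C@H](Nc2c(C(=O)NCc3cccc(C(F)(F)F)c3)nc(Br)c3cccnc23)CC1` — 15000 nM
compound 2 `C[C@H](CO)Nc1nc(C(=O)NCc2ccc(F)cc2)c(O)c2ncccc12` — "not determined" (no result reported)

Compound 1 stands alone on the numbers: in a functional assay on MCF7 cells (Homo sapiens) for cytotoxicity, read by MTT assay, with a stated time of 72 h (a lower number here means a stronger inhibitor, a higher number a weaker inhibitor), compound 1 gives 15000 nM, a weak result, and compound 2 carries no number in this assay ("not determined" (no result reported)). Among the compounds with values here, no step between measured compounds is available, so the series offers a single point and no direction.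

Compound 3 `N[C@H]1CC[C@H](Nc2c(C(=O)NC3CCCCC3)nc(Br)c3cccnc23)CC1` keeps the core of compound 1 and differs at one place: cyclohexyl in place of 3-(trifluoromethyl)benzyl on an amide-type nitrogen. Nothing measured here shows how this place responds to a change; compound 2 differs from compound 1 at several places at once and has no number, so it gives no guidance either.

Within the data shown here, with one point and no step, the expectation for compound 3 rests on compound 1 alone. The step is expected to be small, in either direction, or none beyond the scatter, since the only anchor is the weak value of compound 1 in this assay. The step expected here is a 1.3-fold higher number from compound 1 to compound 3 (0.12 log units; within the scatter). Compound 3 in this assay is estimated at 20000 nM, with a range from 6000 nM to 60000 nM.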

Compound 3, half-maximal inhibitory concentration: 5200 nM
Estimate against measurement, compound 3: 3.8-fold (0.59 log units) above; measured number outside the range, below it.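

The amide nitrogen is now the first place in the series with a readable response: in this assay, cyclohexyl in place of 3-(trifluoromethyl)benzyl gives a 2.9-fold lower number from compound 1 to compound 3 (0.46 log units; beyond the scatter), a modest step. The aromatic ring and the trifluoromethyl group of the leaving 3-(trifluoromethyl)benzyl are therefore not needed for the activity of this pair, and the non-aromatic cyclohexyl, the smaller of the two groups by heavy atoms, gives the lower number. No measured property of either group bears on this step, so it stands as an observation on a single pair.

This one pair cannot separate the loss of the trifluoromethyl group from the exchange of an aromatic ring for a non-aromatic one, and a plain benzyl or a straight hexyl chain on the same nitrogen would be the comparison that pulls these apart. It also leaves open whether the step would hold with a different group in place of the bromine or the aminocyclohexyl part of the shared core, since compound 2 has no number and differs at several places at once.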